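This account rests on a few compounds, and the source may have more. Where it says the series, first, only, none or still open, it means among the compounds named here.

Of the compounds shown here, three built on a shared core have been measured in a physicochemical assay for lipophilicity, at pH 7.4; on this read-out lower numbers stand for lower lipophilicity and higher numbers for higher lipophilicity. Compound 1 `COc1ccc(-c2cc(-c3cccc(S(C)(=O)=O)c3)cnc2N)cn1` gives 2.3 in this assay, and compound 2 `COc1ccc(-c2cc(-c3ccc(S(C)(=O)=O)c(F)c3)cnc2N)cn1` gives 2.5. Compound 3 `COc1ccc(-c2cc(-c3ccc(C(F)(F)F)cc3)cnc2N)cn1` gives 4.2, the highest of the three numbers: it stands above compound 2 by a gap beyond the usual scatter, and above compound 1 by a still wider gap, also beyond the scatter.

Compound 4 `COc1ccc(-c2cc(-c3ccc(C(=O)N(C)C)cc3)cnc2N)cn1` has not yet been measured in this assay. It differs from compound 3 in a single place: dimethylcarbamoyl in place of trifluoromethyl on an aromatic carbon. Among the measured compounds shown here, no pair of measured compounds shows this same change, so the size of the step cannot be read off directly; only the spread of the three measured numbers offers a guide. The expected step of a number 1.60 log units lower from compound 3 to compound 4 (beyond the scatter) in this assay is a downward one, beyond the scatter. The estimate for compound 4 in this assay is 2.6, with a range from 2 to 3.2.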

Compound 4, distribution coefficient: 2.1
Beside the measured number, compound 4's estimate is 0.50 log units above it, and the stated range covers the measured number.
By their numbers in this assay, from the lowest: compounds 4, 1 and 2 (each within the scatter of the next, the first and the last beyond it); then compound 3.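

Among the compounds shown here, replacing trifluoromethyl with dimethylcarbamoyl on an aromatic carbon, para to a large group, gives the first step in this assay that can be read between two compounds differing in one place: a number 2.10 log units lower from compound 3 to compound 4 (beyond the scatter). The step is large, which shows that this read-out can respond strongly to the group at this place on the shared core, at least for this one change. Nothing measured here accounts for the size of the step.

As far as these compounds go, it remains open where other groups at this place, such as an amine, a carboxylic acid or a nitrile, would fall relative to compound 3 and compound 4. From the compounds shown here alone, it is also open whether the same change would give a step of similar size elsewhere on the shared core or in another compound of the series.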